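The source may report more compounds than this note shows. Statements on the series, on what has been measured and on what is new or still open speak of the compounds shown alone.

Working notes on the series. In a toxicity assay on CHO cells (Cricetulus griseus) for cytotoxicity, read by MTT assay (on this read-out higher numbers stand for weaker inhibition and lower numbers for stronger inhibition), compound 1 (`O=C(N/N=C/c1ccc(F)cc1)c1cn(C2CC2)c2cc(N3CCNCC3)c(F)cc2c1=O`) gives 25000 nM, and compound 2 (`COc1ccc(/C=N/NC(=O)c2cn(C3CC3)c3cc(N4CCNCC4)c(F)cc3c2=O)cc1O`) stands level with it at 25000 nM. Compound 3 (`COc1cc(/C=N/NC(=O)c2cn(C3CC3)c3cc(N4CCNCC4)c(F)cc3c2=O)cc(OC)c1OC`) carries 3,4,5-trimethoxyphenyl in place of 3-hydroxy-4-methoxyphenyl on a carbon with a double bond to nitrogen. For the measured compounds named here, the one measured step at this place is no change at the digits printed from compound 1 to compound 2 (within the scatter), so no step beyond the scatter is expected in this assay, in either direction. The expected step is no change at the digits printed from compound 2 to compound 3 (within the scatter). The estimated value for compound 3 is 25000 nM, within an expected range of 12000 nM to 50000 nM.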

Compound 3, half-maximal inhibitory concentration: 25000 nM
The estimate for compound 3 equals the measured number at the digits printed, within the range that was stated.
By their numbers in this assay, from the lowest: compounds 1, 2 and 3 (each within the scatter of the next).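

On the carbon with a double bond to nitrogen, 3,4,5-trimethoxyphenyl gives, in this assay, no change at the digits printed from compound 2 to compound 3 (within the scatter) and no change at the digits printed from compound 1 to compound 3 (within the scatter). This change takes the group from 9 to 12 heavy atoms and from 1 hydrogen-bond donor to 0 without a step beyond the scatter, so this position now tolerates a larger substituent with no donor. No available evidence accounts for this result.

All three groups here are six-membered aromatic rings of carbon only. Going by these compounds, whether a basic amine or a carboxylic acid on that ring, or a longer alkyl chain in its place, would give a step beyond the scatter remains open.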